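Solubility of a trifluoromethyl analogue estimated from a matched pair

A few compounds are considered here, and "the series" means these few. Any claim that something is new, unique, unknown or untested is made for them only; others in the source may bear on it.

Measured compounds:
- compound 1, `Cc1cc(CCC#N)cc(C)c1Oc1cc(Nc2ccc(C#N)cc2)c(N)cc1C(F)(F)F`: 0.24 ug/mL
- compound 2, `COC(=O)c1cc(N)c(Nc2ccc(C#N)cc2)cc1Oc1c(C)cc(CCC#N)cc1C`: 1.21 ug/mL
- compound 3, `COC(=O)c1cc(N)c(Nc2ccc(C#N)cc2)cc1Oc1c(C)cc(/C=C/C#N)cc1C`: 1.3 ug/mL

Of the compounds shown here, three have been measured in a physicochemical assay for solubility, with a stated time of 4 h, at pH 7.4; on this read-out lower numbers stand for lower solubility and higher numbers for higher solubility. Compound 2 and compound 3 share a core and differ only in one side chain: 2-cyanoethenyl in place of 2-cyanoethyl on an aromatic carbon. In this assay this pair gives a 1.1-fold higher number from compound 2 to compound 3 (0.03 log units; within the scatter), so the two values are indistinguishable. Compound 1 and compound 2 differ in one group on the core: trifluoromethyl in place of methoxycarbonyl on an aromatic carbon. Here the step is a 5.0-fold lower number from compound 2 to compound 1 (0.70 log units; beyond the scatter), a clear drop.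

Compound 4, `Cc1cc(/C=C/C#N)cc(C)c1Oc1cc(Nc2ccc(C#N)cc2)c(N)cc1C(F)(F)F`, has not yet been measured. It differs from compound 3 by trifluoromethyl in place of methoxycarbonyl on an aromatic carbon. This is the same change as that from compound 2 to compound 1, and the surroundings of the place are described in the same words in both cases, so the two occurrences are the same change. It occurs twice among the compounds shown, once measured and once not.

Because the earlier occurrence gave a 5.0-fold lower number from compound 2 to compound 1 (0.70 log units; beyond the scatter), a step of similar size is expected from compound 3 to compound 4, namely a 5.0-fold lower number from compound 3 to compound 4 (0.70 log units; beyond the scatter). This rests on a single measured pair, so the expectation carries real uncertainty. Starting from compound 3 with 1.3 ug/mL, compound 4 is estimated at 0.26 ug/mL, with a likely range from 0.1 ug/mL to 0.7 ug/mL.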

Compound 4, solubility: 0.24 ug/mL
For compound 4 the middle estimate is 1.1-fold (0.03 log units) above the measured one; measured number inside the range.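

In this assay, putting trifluoromethyl in place of methoxycarbonyl gives a 5.4-fold lower number from compound 3 to compound 4 (0.73 log units; beyond the scatter), while the same change with 2-cyanoethyl as the side chain gave a 5.0-fold lower number from compound 2 to compound 1 (0.70 log units; beyond the scatter), so both steps lie beyond the scatter and are close in size. The side-chain swap with trifluoromethyl on the core gives no change at the digits printed from compound 1 to compound 4 (within the scatter), and with methoxycarbonyl it gave a 1.1-fold higher number from compound 2 to compound 3 (0.03 log units; within the scatter), so 2-cyanoethenyl and 2-cyanoethyl cannot be told apart in either setting. This shows the change carrying over between two closely related compounds whose cores differ only in that side chain, but it does not show that the step would hold on a more different core, and no measurement shown bears on why the number falls.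

On these data alone, it remains open whether the step would keep its size if the side chain were a longer chain or a carboxylic acid, and how an amine in place of trifluoromethyl or methoxycarbonyl would compare. All of these numbers also come from this assay alone, so they say nothing about how the same change behaves on any other read-out.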